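The compounds below may be only part of what the source reports. "The series", "measured", "known", "first", "only" and "open" are said of these compounds alone.

In this study the shared core carries an acetyl group on a five-membered non-aromatic ring with two nitrogens, and the variable group sits on a saturated ring carbon of that ring. Compound 1 `CC(=O)N1N=C(Nc2nc3ccccc3s2)CC1c1ccc(Cl)cc1` is the reference: in a functional assay on the whole organism (Hindlimb, strain albino) with Mus musculus as the target, in the maximal electroshock model, with a stated time of 0.5 h (on this read-out higher numbers stand for an effect only at larger amounts of compound and lower numbers for an effect already at smaller amounts), compound 1 gives 209 umol/kg. Compound 2 `CC(=O)N1N=C(Nc2nc3ccccc3s2)CC1OC1=CC=C1` carries the change a group of 5 heavy atoms (4 carbon, 1 oxygen; one four-membered non-aromatic ring of carbon only) in place of a group of 7 heavy atoms (6 carbon, 1 chlorine; one six-membered aromatic ring of carbon only), on a saturated ring carbon and in this assay compound 2 gives 382 umol/kg, so that a 1.8-fold higher number from compound 1 to compound 2 (0.26 log units; within the scatter). Compound 3 `CC(=O)N1N=C(Nc2nc3ccc(Cl)cc3s2)CC1c1ccc(Cl)cc1` differs from compound 1 in its core by chloro in place of hydrogen on an aromatic carbon; in this assay compound 3 gives 79.5 umol/kg, and a 2.6-fold lower number from compound 1 to compound 3 (0.42 log units; beyond the scatter), leaving compound 3 with the lowest number of the three.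

Compound 4 `CC(=O)N1N=C(Nc2nc3ccc(Cl)cc3s2)CC1OC1=CC=C1` has not yet been measured. It stands to compound 3 as compound 2 stands to compound 1, since a group of 5 heavy atoms (4 carbon, 1 oxygen; one four-membered non-aromatic ring of carbon only) in place of a group of 7 heavy atoms (6 carbon, 1 chlorine; one six-membered aromatic ring of carbon only), on a saturated ring carbon is the same change, made at the same place on a saturated ring carbon of the five-membered non-aromatic ring with two nitrogens. For the measured compounds named here, only one earlier instance of this change is known, and it lies within the scatter, so the expectation rests on a single step. In this assay compound 4 is expected to fall at 140 umol/kg, with a range from 75 umol/kg to 280 umol/kg, because the step of a 1.8-fold higher number from compound 1 to compound 2 (0.26 log units; within the scatter) was small. The expected step is therefore a 1.8-fold higher number from compound 3 to compound 4 (0.25 log units; within the scatter), which the coming measurement will test.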

Compound 4, dose for half-maximal effect: 212 umol/kg
Compound 4: middle estimate off by 1.5-fold (0.18 log units), on the low side, and the stated range covers the measured number.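

In this assay the swap of the 4-chlorophenyl group for the group with the four-membered ring, made on the chlorinated core, gives a 2.7-fold higher number from compound 3 to compound 4 (0.43 log units; beyond the scatter), and it agrees with the same swap on the core of compound 1: the same change on two cores in this assay, a 1.8-fold higher number (0.26 log units; within the scatter) from compound 1 to compound 2 and a 2.7-fold higher number (0.43 log units; beyond the scatter) from compound 3 to compound 4, 1.5-fold (0.16 log units) apart, within the scatter of two such steps. Read the other way round, chloro in place of hydrogen on an aromatic carbon gives a 1.8-fold lower number from compound 2 to compound 4 (0.26 log units; within the scatter), and this too agrees with its earlier counterpart: the same change on two cores in this assay, a 2.6-fold lower number (0.42 log units; beyond the scatter) from compound 1 to compound 3 and a 1.8-fold lower number (0.26 log units; within the scatter) from compound 2 to compound 4, 1.5-fold (0.16 log units) apart, within the scatter of two such steps. For the compounds shown here, the four compounds therefore show that each change carried over between these two cores with no gap beyond the scatter, although they do not show that either step has a fixed size, since one member of each pair lies within the scatter and the other beyond it, and they rest on only two cores and a single read-out.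

The compounds shown leave open whether the same carry-over would hold for other groups on the saturated ring carbon, such as an amine, a carboxylic acid or a longer alkyl chain. They also leave open whether a fluoro or methoxy group on the same aromatic carbon would follow the chloro step on either core.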